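Series notes: aryl change on the ring nitrogen of compound 2

The source may report more compounds than this note shows. Statements on the series, on what has been measured and on what is new or still open speak of the compounds shown alone.

Compound 1 `FC(F)(F)c1ccc(CSc2nc(Nc3ccccc3Cl)c3ccccc3n2)cc1` is the starting point. In a functional assay on MCF7 cells (Homo sapiens) for cytotoxicity, read by MTT assay, with a stated time of 72 h (a lower number here means a stronger inhibitor, a higher number a weaker inhibitor), compound 1 returns only a limit, > 50000 nM. Compound 2 `CCOc1ccccc1Nc1nc(SCc2ccc(C(F)(F)F)cc2)nc2ccccc12`, with ethoxy in place of chloro on an aromatic carbon, likewise gives only a limit in this assay, namely > 50000 nM. The step that the two limits leave unreadable from compound 1 to compound 2 is therefore unreadable, both values sitting at the limit of > 50000 nM in this assay, at which 2 of the 2 values shown sit. Compound 3 `Fc1ccc(Nc2nc(SCc3ccc(C(F)(F)F)cc3)nc3ccccc23)cc1` differs from compound 2 by 4-fluorophenyl in place of 2-ethoxyphenyl on a nitrogen on an aromatic ring. No readable measured step bears on this change, so nothing beyond the scatter is expected. The estimated step is a step that the limit leaves unreadable from compound 2 to compound 3. Compound 3 is expected near 60000 nM, between 20000 nM and 200000 nM, most likely again reported as a limit.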

Compound 3, half-maximal inhibitory concentration: 36300 nM
Compound 3: middle estimate off by 1.7-fold (0.22 log units), on the high side, within the range that was stated.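

Compound 3 is the only compound shown that returns a number rather than a limit in this assay, with 4-fluorophenyl on the nitrogen: the limit of > 50000 nM in this assay, at which 2 of the 3 values shown sit. Replacing 2-ethoxyphenyl gives an at least 1.3-fold lower number from compound 2 to compound 3 (0.13 log units; that floor lies within the scatter), and replacing 2-chlorophenyl gives an at least 1.3-fold lower number from compound 1 to compound 3 (0.13 log units; that floor lies within the scatter). Each is only a floor, so neither establishes a real gain at this position, and the step between compound 1 and compound 2 cannot be read.

From the compounds shown here alone, the true size of both steps remains open. So does how an amine or a carboxylic acid on this aryl ring would read.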